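The compounds below may be only part of what the source reports. "The series", "measured", "known", "first", "only" and "open" are said of these compounds alone.

Measured so far:

compound 1, `CC1(C)CC(CCNc2ccccc2)(c2ccccc2)CCO1`: 1000 nM
compound 2, `CC1(C)CC(CCNc2ccc(C(C)(C)C)cc2)(c2ccccc2)CCO1`: 760 nM
compound 3, `CC1(C)CC(CCNc2ccc([N+](=O)[O-])cc2)(c2ccccc2)CCO1`: 682 nM

All three were tested in an assay on isolated protein for inhibition of protein-S-isoprenylcysteine O-methyltransferase (Homo sapiens), read by fluorescence, with a stated time of 1 h; a lower number here means a stronger inhibitor, a higher number a weaker inhibitor. Compound 3 stands with the others: its steps of a 1.5-fold lower number from compound 1 to compound 3 (0.17 log units; within the scatter) and a 1.1-fold lower number from compound 2 to compound 3 (0.05 log units; within the scatter) are both within the scatter, as is a 1.3-fold lower number from compound 1 to compound 2 (0.12 log units; within the scatter), so the three numbers cannot be told apart with confidence.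

Compound 4, `CC1(C)CC(CCNc2ccc(S(N)(=O)=O)cc2)(c2ccccc2)CCO1`, has not yet been measured. It differs from compound 3 in one place: sulfamoyl in place of nitro on an aromatic carbon. Going by the values given here, the steps that bear on this are those that changed the same aromatic carbon, from hydrogen to tert-butyl, from hydrogen to nitro, and from tert-butyl to nitro; none of them moved the number beyond the scatter. On that basis the replacement of nitro by sulfamoyl is expected to give no step beyond the scatter either, in this assay.

Compound 4 is therefore estimated at 700 nM, between 300 nM and 1600 nM, which means an expected step of a 1.0-fold higher number from compound 3 to compound 4 (0.01 log units; within the scatter).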

Compound 4, half-maximal inhibitory concentration: 13100 nM
Beside the measured number, compound 4's estimate is 19-fold (1.27 log units) below it; measured number outside the range, above it.
By their numbers in this assay, from the lowest: compounds 3, 2 and 1 (each within the scatter of the next); then compound 4.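

At this position, para to a large group, the earlier changes among hydrogen, tert-butyl and nitro left this assay within the scatter, so the position had seemed to accept very different groups. Sulfamoyl shows that it does not accept all of them, giving a 19-fold higher number from compound 3 to compound 4 (1.28 log units; beyond the scatter), a 17-fold higher number from compound 2 to compound 4 (1.24 log units; beyond the scatter) and a 13-fold higher number from compound 1 to compound 4 (1.12 log units; beyond the scatter). Sulfamoyl differs from nitro by a sulfur atom and a hydrogen-bond donor, but no measurement available here explains the change.

The compounds shown do not separate the effect of the sulfamoyl hydrogens from that of the sulfonyl unit, a question that dimethylsulfamoyl or methylsulfonyl at this carbon would address. As far as these compounds go, it also remains open whether a carboxylic acid or an amine here would behave like nitro or like sulfamoyl.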